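The source may hold more compounds than are shown below. What is called first, only, known or untested is meant among the compounds shown, and "the series" means these compounds.

Measured compounds:
compound 1, `Oc1cccc(-c2cc(-c3ccncc3)nc(-c3ccccc3Cl)c2)c1`: "not determined" (no result reported) in a functional assay on DU-145 cells (Homo sapiens) for cytotoxicity, read by CCK-8 assay and cell counting, with a stated time of 2 days; on this read-out higher numbers stand for weaker inhibition and lower numbers for stronger inhibition
compound 2, `Oc1cccc(-c2cc(-c3ccncc3)nc(-c3cccc(Cl)c3)c2)c1`: "not determined" (no result reported) in this assay
compound 3, `Oc1cccc(-c2cc(-c3ccncc3)nc(-c3ccc(Cl)cc3)c2)c1`: 2510 nM

Compound 1 stands without a single number in this assay, and compound 2 is a further entry without one; only compound 3 gives a value here. Compound 4, `Oc1cccc(-c2cc(-c3cccs3)nc(-c3ccccc3Cl)c2)c1`, differs from compound 1 by thiophen-2-yl in place of pyridin-4-yl on an aromatic carbon. Going by the values given here, with no measured step of this kind on record, the size and direction of the change from compound 1 to compound 4 cannot be read from the data, so any step beyond the scatter is uncertain. Taking the value of compound 3 as the only anchor, compound 4 is expected to come in near 3000 nM, in a range from 500 nM to 20000 nM.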

Compound 4, half-maximal inhibitory concentration: 1700 nM
Compound 4: middle estimate off by 1.8-fold (0.25 log units), on the high side; the range from low to high includes it.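

Going by these compounds alone, compound 1 has no single number to set against compound 4, so no step between them can be read. The effect of swapping pyridin-4-yl for thiophen-2-yl stays open, and nothing shown explains the value of compound 4.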